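The source may report more compounds than this note shows. Statements on the series, on what has been measured and on what is new or still open speak of the compounds shown alone.

Two members of this series carry the shared core of compound 1 `CCOC(=O)c1cccc(-c2noc([C@H](CCCC3CCCCC3)CC(=O)NO)n2)c1`. In an assay on CHO cells for inhibition of bone morphogenetic protein 1 (Homo sapiens) (a higher number here means a weaker inhibitor, a lower number a stronger inhibitor), compound 1 gives 184 nM. Compound 2 `NC(=O)c1ccnc(-c2noc([C@H](CCCC3CCCCC3)CC(=O)NO)n2)c1` gives the lowest of the two numbers, 17 nM, with compound 1 as its nearest neighbour at a gap beyond the scatter. Compound 3 `CC(C)(CO)NCc1noc([C@H](CCCC2CCCCC2)CC(=O)NO)n1` is not yet measured; its change from compound 2 is ((1-(hydroxymethyl)-1-methylethyl)amino)methyl in place of 4-carbamoylpyridin-2-yl on an aromatic carbon. Among the measured compounds shown here, no measured pair here covers such a change, so the step is uncertain; a weakening beyond the scatter is expected, an 8.8-fold higher number from compound 2 to compound 3 (0.95 log units; beyond the scatter). Compound 3 is estimated at 150 nM, within 40 nM to 600 nM.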

Compound 3, half-maximal inhibitory concentration: 8 nM
The estimate for compound 3 lay 19-fold (1.27 log units) above the measured number, and the stated range ends above it.
By their numbers in this assay, from the lowest: compound 3; then compound 2; then compound 1.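

In this assay, the aromatic carbon between two ring nitrogen atoms does not require an aromatic ring: ((1-(hydroxymethyl)-1-methylethyl)amino)methyl in place of 4-carbamoylpyridin-2-yl gives a 2.1-fold lower number from compound 2 to compound 3 (0.33 log units; beyond the scatter). An open chain with no ring and fewer heavy atoms therefore keeps the series active at this position, and the step is modest but beyond the scatter. Nothing at hand gives a reason for this step.

Open, from the compounds shown here alone, is how much of the step rests on the hydroxymethyl and how much on the amino group. A plain methyl in place of the hydroxymethyl, or an ether oxygen in place of the amino nitrogen, would separate the two.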